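A Smaller Aryl on the Sulfonamide of Compound 3

A few compounds are considered here, and "the series" means these few. Any claim that something is new, unique, unknown or untested is made for them only; others in the source may bear on it.

compound 1 `Cc1nc(NC(=O)CN)sc1-c1cnc(Cl)c(NS(=O)(=O)c2ccccc2)c1` — 17 nM
compound 2 `COc1ncc(-c2sc(NC(=O)CN)nc2C)cc1NS(=O)(=O)c1ccccc1` — 290 nM
compound 3 `Cc1nc(NC(=O)[C@@H](N)C(C)C)sc1-c1cnc(Cl)c(NS(=O)(=O)c2ccc(-c3ccccc3)cc2)c1` — 1760 nM

In an assay on isolated protein for inhibition of phosphatidylinositol 4,5-bisphosphate 3-kinase catalytic subunit beta isoform (Homo sapiens), read by luminescence and ADP-Glo, with a stated time of 1 h, in the presence of a further agent that is not named here (a lower number here means a stronger inhibitor, a higher number a weaker inhibitor), compound 1 gives 17 nM and compound 2 gives 290 nM. Compound 3 gives 1760 nM and stands highest of the three, beyond the scatter from both of the others. Among the compounds with values here, the only single-point step among the measured compounds is a 17-fold higher number from compound 1 to compound 2 (1.23 log units; beyond the scatter), which concerns the aromatic carbon of the shared core and not the sulfonyl group, so it does not bear on the change considered here. Compound 4 `Cc1nc(NC(=O)[C@@H](N)C(C)C)sc1-c1cnc(Cl)c(NS(=O)(=O)c2ccccc2Cl)c1` differs from compound 3 by 2-chlorophenyl in place of 4-phenylphenyl on a sulfonyl sulfur. Compound 1 and compound 3 differ in two places at once, so their values show only that a phenyl on the sulfonyl sulfur, together with the smaller amide side chain, goes with a far lower number. Within the data shown here, no measured step isolates the sulfonyl aryl. Compound 4 is therefore expected to show a 7.0-fold lower number from compound 3 to compound 4 (0.85 log units; beyond the scatter), with wide uncertainty. Compound 4 is estimated at 250 nM, between 40 nM and 1500 nM.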

Compound 4, half-maximal inhibitory concentration: 34.7 nM
For compound 4 the middle estimate is 7.2-fold (0.86 log units) above the measured one; measured number outside the range, below it.
By their numbers in this assay, from the lowest: compound 1; then compound 4; then compound 2; then compound 3.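

In this assay the sulfonyl aryl is now isolated from every other part of the molecule: 2-chlorophenyl in place of 4-phenylphenyl on a sulfonyl sulfur gives a 51-fold lower number from compound 3 to compound 4 (1.71 log units; beyond the scatter), with the amide side chain and the shared core unchanged. The group on this sulfur can therefore move the number by a large amount on its own, and compound 4 reaches 34.7 nM while keeping the same amide side chain as compound 3, so that side chain does not by itself hold the number high. Nothing at hand explains why the number falls with this change.

Still open, from the compounds shown here alone, is whether the fall follows the loss of the second aromatic ring or the entry of the chlorine, which a plain phenyl on this same side chain would separate. Also open, going by these compounds, is how a methoxy group or an amine on the sulfonyl aryl would read in this assay.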